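From Carbamate Carbonyl to Amine: Expecting Compound 4

A few compounds are considered here, and "the series" means these few. Any claim that something is new, unique, unknown or untested is made for them only; others in the source may bear on it.

Compound 3 `CS(=O)(=O)c1cnc(O[C@H]2CC[C@H](OC3CCN(C(=O)C4(C(F)(F)F)CCCC4)CC3)CC2)cn1` gives 108 nM in a functional assay on isolated protein for agonist activity at Glucose-dependent insulinotropic receptor (Rattus norvegicus), read by HTRF and cAMP accumulation (on this read-out higher numbers stand for an effect only at larger amounts of compound and lower numbers for an effect already at smaller amounts), the second highest of the three numbers measured. Compound 2 `CS(=O)(=O)c1cnc(O[C@H]2CC[C@H](OC3CCN(C(=O)Oc4ccccc4)CC3)CC2)cn1` gives 71.8 nM, and the step of a 1.5-fold higher number from compound 2 to compound 3 (0.18 log units; within the scatter) stays within the scatter. Compound 1 `CS(=O)(=O)c1cnc(O[C@H]2CC[C@H](OC3CCN(C(=O)OC4CCOC4)CC3)CC2)cn1` gives 1500 nM; the steps of a 14-fold lower number from compound 1 to compound 3 (1.14 log units; beyond the scatter) and a 21-fold lower number from compound 1 to compound 2 (1.32 log units; beyond the scatter) are both large. Compound 4 `CS(=O)(=O)c1cnc(O[C@H]2CC[C@H](OC3CCN(CC4(C(F)(F)F)CCC4)CC3)CC2)cn1` differs from compound 3 by a group of 9 heavy atoms (6 carbon, 3 fluorine; one four-membered non-aromatic ring of carbon only) in place of a group of 11 heavy atoms (7 carbon, 1 oxygen, 3 fluorine; one five-membered non-aromatic ring of carbon only), on an amine nitrogen in a ring, so the carbonyl is lost. For the measured compounds named here, no measured step removes a carbonyl; the steps that alter the group on the carbonyl carbon range from within the scatter to large, so a moderate shift in either direction remains possible. Compound 4 is expected near 220 nM, between 60 nM and 800 nM. The expected step of a 2.0-fold higher number from compound 3 to compound 4 (0.31 log units; beyond the scatter) leans toward a somewhat higher number.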

Compound 4, half-maximal effective concentration: 80 nM
For compound 4 the middle estimate is 2.8-fold (0.44 log units) above the measured one; low and high end bracket the measured number.
By their numbers in this assay, from the lowest: compounds 2, 4 and 3 (each within the scatter of the next); then compound 1.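

With the carbonyl gone from the amine nitrogen in a ring, the number in this assay holds, since a 1.4-fold lower number from compound 3 to compound 4 (0.13 log units; within the scatter) and a 1.1-fold higher number from compound 2 to compound 4 (0.05 log units; within the scatter) both stay within the scatter. The (1-(trifluoromethyl)cyclobutyl)methyl group thus matches both carbonyl-linked groups without any hydrogen-bond acceptor of its own. Only a 19-fold lower number from compound 1 to compound 4 (1.27 log units; beyond the scatter) is large, leaving compound 1 apart from the other three. Nothing available explains this result. Still open, going by these compounds, is whether a cyclobutylmethyl group without the trifluoromethyl, or a benzyl group, on that nitrogen would stay at this level.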